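Working notes: the step from compound 3 to compound 4

The source may report more compounds than this note shows. Statements on the series, on what has been measured and on what is new or still open speak of the compounds shown alone.

compound 1 `COc1cc(N2C(=O)[C@@H](Oc3ccccc3)[C@H]2c2ccc(C#N)cc2)cc(OC)c1OC`: 31600 nM
compound 2 `COc1cc(N2C(=O)[C@@H](Oc3ccccc3)[C@H]2c2cccc3ccccc23)cc(OC)c1OC`: 53000 nM
compound 3 `COc1cc(N2C(=O)[C@@H](Oc3ccccc3)[C@H]2c2cc(O)c(OC)c([N+](=O)[O-])c2)cc(OC)c1OC`: 69000 nM

In a functional assay on MCF7 cells (Homo sapiens) for antiproliferative activity, read by MTT assay, with stated times of 24 h and 72 h (on this read-out lower numbers stand for stronger inhibition and higher numbers for weaker inhibition), compound 3 stands at 69000 nM, with a 1.3-fold higher number from compound 2 to compound 3 (0.11 log units; within the scatter) and a 2.2-fold higher number from compound 1 to compound 3 (0.34 log units; beyond the scatter). Compound 4 `COc1ccc([C@@H]2[C@H](Oc3ccccc3)C(=O)N2c2cc(OC)c(OC)c(OC)c2)c(N)c1O` is not yet measured and differs by a group of 10 heavy atoms (7 carbon, 1 nitrogen, 2 oxygen; one six-membered aromatic ring of carbon only) in place of a group of 12 heavy atoms (7 carbon, 1 nitrogen, 4 oxygen; one six-membered aromatic ring of carbon only), on a saturated ring carbon. Those two steps bear on it, along with a 1.7-fold higher number from compound 1 to compound 2 (0.22 log units; within the scatter), since all three are exchanges on the same saturated ring carbon. None is large, so a small step is expected. Within the data shown here, no measured compound carries the entering group, so the range stays wide. A tentative lean toward compound 1 at 31600 nM is expected. The expected step is a 2.0-fold lower number from compound 3 to compound 4 (0.29 log units; within the scatter). For compound 4 the estimated value is 35000 nM, with an expected range of 4000 nM to 100000 nM.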

Compound 4, half-maximal inhibitory concentration: 19000 nM
Beside the measured number, compound 4's estimate is 1.8-fold (0.27 log units) above it; measured number inside the range.
By their numbers in this assay, from the lowest: compounds 4, 1, 2 and 3 (each within the scatter of the next, the first and the last beyond it).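

In this assay, the saturated ring carbon of the four-membered ring now shows steps beyond the scatter: the entering group of 10 heavy atoms gives a 3.6-fold lower number from compound 3 to compound 4 (0.56 log units; beyond the scatter) and a 2.8-fold lower number from compound 2 to compound 4 (0.45 log units; beyond the scatter). In place of the 4-cyanophenyl group, however, it gives a 1.7-fold lower number from compound 1 to compound 4 (0.22 log units; within the scatter), so these two groups remain unseparated at this position. Still open, from the compounds shown here alone, is how a group carrying a carboxylic acid or a dimethylamino substituent would read at this carbon. No available evidence accounts for these steps.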